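The source may report more compounds than this note shows. Statements on the series, on what has been measured and on what is new or still open speak of the compounds shown alone.

In an assay for inhibition of Amine oxidase [flavin-containing] B (Rattus norvegicus) (on this read-out higher numbers stand for weaker inhibition and lower numbers for stronger inhibition), compound 2 `COc1ccc(COc2ccc(-c3nn(CCC#N)c(=O)o3)cc2)cc1` gives 27 nM, the higher of the two numbers measured; compound 1 `N#CCCn1nc(-c2ccc(OCc3ccccc3)cc2)oc1=O` gives 2.2 nM. Among the measured compounds shown here, the single measured step, a 12-fold higher number from compound 1 to compound 2 (1.09 log units; beyond the scatter), comes from adding methoxy where hydrogen stood. Compound 3 `Cc1cccc(COc2ccc(-c3nn(CCC#N)c(=O)o3)cc2)c1` differs from compound 2 by 3-methylphenyl in place of 4-methoxyphenyl on a saturated chain carbon bound to an oxygen on an aromatic ring. For the measured compounds named here, since the methoxy leaves, and its arrival earlier produced a 12-fold higher number from compound 1 to compound 2 (1.09 log units; beyond the scatter), a move back toward lower numbers is expected, although the entering methyl has no counterpart among the measured compounds. Compound 3 is therefore estimated at 6 nM, between 1.5 nM and 25 nM, expected as a 4.5-fold lower number from compound 2 to compound 3 (0.65 log units; beyond the scatter).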

Compound 3, half-maximal inhibitory concentration: 8 nM
For compound 3 the middle estimate is 1.3-fold (0.12 log units) below the measured one, within the range that was stated.
By their numbers in this assay, from the lowest: compound 1; then compound 3; then compound 2.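

Replacing 4-methoxyphenyl with 3-methylphenyl on this saturated chain carbon gives a 3.4-fold lower number from compound 2 to compound 3 (0.53 log units; beyond the scatter) in this assay, so the number depends on which group the ring carries. A methyl also costs inhibition relative to the bare ring, with a 3.6-fold higher number from compound 1 to compound 3 (0.56 log units; beyond the scatter), so compound 1 remains lower than both substituted compounds. No supporting data explain these differences.

Because the group and its ring position change together from compound 2 to compound 3, their separate contributions remain unresolved. As far as these compounds go, whether a chlorine or an amine on this ring would also raise the number remains open.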